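Aryl substituent variation on the benzylamine arm

A few compounds are considered here, and "the series" means these few. Any claim that something is new, unique, unknown or untested is made for them only; others in the source may bear on it.

Measured so far:
compound 1, `CC(C)(C)c1ccc(CNCCCNS(=O)(=O)c2cc(C(F)(F)F)cc(C(F)(F)F)c2)cc1`, gives 2100 nM in a functional assay on MCF7 cells (Homo sapiens) for inhibition, read by MTT assay, with a stated time of 72 h; on this read-out higher numbers stand for weaker inhibition of growth and lower numbers for stronger inhibition of growth
compound 2, `O=S(=O)(NCCCNCc1ccccc1)c1cc(C(F)(F)F)cc(C(F)(F)F)c1`, gives 3000 nM in this assay

Within the data shown here, compound 1 stands lowest of the two numbers, but its only neighbour is compound 2, and the step between them, a 1.4-fold higher number from compound 1 to compound 2 (0.15 log units; within the scatter), lies within the scatter: hydrogen in place of tert-butyl on an aromatic carbon leaves the read-out essentially unchanged. Compound 3, `COc1cccc(CNCCCNS(=O)(=O)c2cc(C(F)(F)F)cc(C(F)(F)F)c2)c1`, has not yet been measured in this assay. It differs from compound 1 by 3-methoxyphenyl in place of 4-(tert-butyl)phenyl on a saturated chain carbon bound to an amine nitrogen. Among the measured compounds shown here, the one measured step that bears on this position, a 1.4-fold higher number from compound 1 to compound 2 (0.15 log units; within the scatter), indicates that the substituent on this aromatic ring has little influence, so a change to another small substituent is expected to move the number no further than that. No step beyond the scatter is therefore anticipated, with at most a slight drift toward a higher number in line with what compound 2 shows. Compound 3 is expected at about 2800 nM, with a range of 1300 nM to 6000 nM. The estimated step is a 1.3-fold higher number from compound 1 to compound 3 (0.12 log units; within the scatter), inside the scatter.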

Compound 3, concentration for 50% growth inhibition: 2400 nM
Compound 3: the middle estimate sits 1.2-fold (0.07 log units) above what was measured; the measured number falls inside the stated range.
By their numbers in this assay, from the lowest: compounds 1, 3 and 2 (each within the scatter of the next).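

In this assay, the change from 4-(tert-butyl)benzyl to 3-methoxybenzyl gives a 1.1-fold higher number from compound 1 to compound 3 (0.06 log units; within the scatter) and stays within the scatter, as does methoxy in place of hydrogen on an aromatic carbon, which gives a 1.3-fold lower number from compound 2 to compound 3 (0.10 log units; within the scatter) in the same read-out. The earlier pair tested only the loss of tert-butyl, whereas compound 3 adds a substituent of another kind, one that brings an oxygen and a hydrogen-bond acceptor, and it still cannot be told apart from either compound 1 or compound 2, so the bare phenyl, 4-(tert-butyl)phenyl and 3-methoxyphenyl arms read as equivalent here. No measurement at hand offers an explanation for this flat picture.

On these data alone, the three compounds cover only these neutral ring substituents on an otherwise unchanged core, so it remains open whether an amine or a carboxylic acid on the aromatic ring would produce a step beyond the scatter. Also open, as far as these compounds go, is how much of the growth inhibition depends on the shared core, for example whether a longer chain between its two nitrogens would shift the number.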